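This account rests on a few compounds, and the source may have more. Where it says the series, first, only, none or still open, it means among the compounds named here.

In a functional assay on MCF7 cells (Homo sapiens) for inhibition, read by MTT assay, with a stated time of 72 h (on this read-out lower numbers stand for stronger inhibition and higher numbers for weaker inhibition), compound 1 `COc1cc(NC(C)CCCNC(=O)Nc2cccc(Cl)c2)c2ncccc2c1` gives 11000 nM and compound 2 `COc1cc(NC(C)CCCNC(=O)Nc2ccc(Br)cc2)c2ncccc2c1` gives 2600 nM. Compound 3 `COc1cc(NC(C)CCCNC(=O)NNC(=O)Nc2ccc(F)cc2)c2ncccc2c1` gives 310 nM, the lowest number of the three and therefore the strongest inhibition so far. The next compound, compound 4 `COc1cc(NC(C)CCCNC(=O)NNC(=O)Nc2ccc(Cl)cc2)c2ncccc2c1`, differs from compound 3 at a single spot: chloro in place of fluoro on an aromatic carbon. In words, this is chloro in place of fluoro on an aromatic carbon, para to a large group.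

Among the measured compounds shown here, no measured pair tests this swap directly. The two biggest steps, a 35-fold lower number from compound 1 to compound 3 (1.55 log units; beyond the scatter) and an 8.4-fold lower number from compound 2 to compound 3 (0.92 log units; beyond the scatter), both bring in the ((4-fluorophenyl)carbamoyl)amino group in place of a halogen-bearing phenyl group. Compound 4 keeps the carbamoyl-amino part of that group, so these steps say little about exchanging one halogen for another. The closest guide is a 4.2-fold lower number from compound 1 to compound 2 (0.63 log units; beyond the scatter), a modest step, but there 4-bromophenyl replaces 3-chlorophenyl, so the halogen and its place on the ring change together.

With such indirect evidence, no direction is favoured, and the estimate stays close to compound 3 at 310 nM. The expected result is a 1.0-fold lower number from compound 3 to compound 4 (0.01 log units; within the scatter), which would be no change beyond the scatter. For compound 4, the estimated value is 300 nM, with an expected range of 120 nM to 750 nM.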

Compound 4, half-maximal inhibitory concentration: 180 nM
Compound 4: the middle estimate sits 1.7-fold (0.22 log units) above what was measured; the measured number falls inside the stated range.
By their numbers in this assay, from the lowest: compounds 4 and 3 (each within the scatter of the next); then compound 2; then compound 1.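

In this assay, the change from fluoro to chloro on this aromatic carbon, para to a large group, gives a 1.7-fold lower number from compound 3 to compound 4 (0.24 log units; within the scatter) and so offers the first direct test of one halogen against the other at this place, showing no difference that can be told from the scatter. Both halogens are therefore tolerated here, at least in this series, and the low numbers of compound 3 are not tied to fluoro alone. The ((4-chlorophenyl)carbamoyl)amino group also keeps the clear advantage over the simpler aryl groups, with a 14-fold lower number from compound 2 to compound 4 (1.16 log units; beyond the scatter) on replacing 4-bromophenyl and a 61-fold lower number from compound 1 to compound 4 (1.79 log units; beyond the scatter) on replacing 3-chlorophenyl, while nothing shown here offers an explanation for these numbers.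

From the compounds shown here alone, whether bromo, methyl, methoxy, a nitrile or plain hydrogen at this place would give similar numbers remains open, since only two halogens have been compared here. Also open, going by these compounds, is how much of the large steps belongs to the carbamoyl-amino part itself, since in those steps the ring substituent changes along with it, and a direct comparison would need a pair that differs in that part alone.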